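The compounds below may be only part of what the source reports. "The series", "measured", "known", "first", "only" and "open" are said of these compounds alone.

Compound 1 `COc1cc(-c2nn(-c3cccc(NC(=O)c4cccc(C(F)(F)F)c4)c3)cc2-c2ccncc2)ccc1Cl` gives > 50000 nM in a functional assay on M14 cells (Homo sapiens) for inhibition, read by sulforhodamine B assay, with a stated time of 48 h (a higher number here means a weaker inhibitor of growth, a lower number a stronger inhibitor of growth), and this value is a limit of the assay. Compound 2 `COc1cc(-c2nn(-c3cccc(NC(=O)Nc4ccc(Cl)c(Cl)c4)c3)cc2-c2ccncc2)ccc1Cl` gives 2690 nM in this assay. Compound 3 `COc1cc(-c2nn(-c3cccc(NC(=O)Nc4cccc(C(F)(F)F)c4)c3)cc2-c2ccncc2)ccc1Cl` gives 1870 nM in this assay.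

Compound 3 holds the lowest of the two numbers; its nearest neighbour is compound 2, and a 1.4-fold lower number from compound 2 to compound 3 (0.16 log units; within the scatter) lies within the scatter. Compound 4 `COc1cc(-c2nn(-c3cccc(NC(=O)c4ccc(Cl)c(C(F)(F)F)c4)c3)cc2-c2ccncc2)ccc1Cl` differs from compound 3 by 4-chloro-3-(trifluoromethyl)phenyl in place of (3-(trifluoromethyl)phenyl)amino on a carbonyl carbon. This runs the other way from the measured steps in which the 3-(trifluoromethyl)phenyl on the carbonyl carbon of compound 1 was exchanged for an arylamino: an at least 18-fold lower number from compound 1 to compound 2 (1.26 log units; beyond the scatter) and an at least 26-fold lower number from compound 1 to compound 3 (1.42 log units; beyond the scatter), both large, both starting from the limit of > 50000 nM in this assay, at which 1 of the 3 values shown sits. A large upward step is therefore expected, a 21-fold higher number from compound 3 to compound 4 (1.33 log units; beyond the scatter), with a fair chance that only a limit is returned. Compound 4 is estimated at 40000 nM, within 10000 nM to 120000 nM.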

Compound 4, concentration for total growth inhibition: > 32500 nM
Compound 4 was reported as a limit; the forecaster's own chance of this, stated with the estimate: 55%; the middle value is on the limit's open side.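

With an aryl group in place of the arylamino on the carbonyl carbon, the large loss now also shows from the measured side, as an at least 17-fold higher number from compound 3 to compound 4 (1.24 log units; beyond the scatter) and as an at least 12-fold higher number from compound 2 to compound 4 (1.08 log units; beyond the scatter). Compound 4 is reported only as a limit: the limit of > 32500 nM in this assay, at which 1 of the 4 values shown sits. The step between compounds 1 and 4 cannot be read, so adding chloro to the aryl group on the carbonyl carbon shows no readable effect. Still open, on these data alone, is whether a methylene or an oxygen in place of the nitrogen on the carbonyl carbon would keep the lower numbers of compounds 2 and 3.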